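The source may report more compounds than this note shows. Statements on the series, on what has been measured and on what is new or still open speak of the compounds shown alone.

Compound 1 `CC(C)S(=O)(=O)N1CCC(CN(C2Cc3cc(C#N)ccc3N(Cc3cncn3C)C2)S(=O)(=O)c2ccccn2)CC1` gives 0.1 10^-6 cm/s in an ADME assay on Caco-2 cells (Homo sapiens) for permeability, in the apical to basolateral direction; a higher number here means that the compound crosses the layer faster, a lower number that the compound crosses the layer more slowly. Among the compounds with values here, its nearest neighbour is compound 2 `Cn1cnc(S(=O)(=O)N2CCC(CN(C3Cc4cc(C#N)ccc4N(Cc4cncn4C)C3)S(=O)(=O)c3ccccn3)CC2)c1`, which in this assay gives 0.1 10^-6 cm/s; the one measured step, no change at the digits printed from compound 1 to compound 2 (within the scatter), exchanges the group on the sulfonyl sulfur and leaves the read-out level. Compound 1 therefore stands level with compound 2 at the digits shown, at the low end of the measured range.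

Compound 3 `Cn1cncc1CN1CC(N(CC2CCN(C(=O)N3CCCCC3)CC2)S(=O)(=O)c2ccccn2)Cc2cc(C#N)ccc21` is not yet measured. It differs from compound 1 as follows: (piperidin-1-yl)carbonyl in place of isopropylsulfonyl on an amine nitrogen in a ring. Within the data shown here, no measured step covers this exchange: the only step recorded touches the same sulfonyl position but keeps a sulfonyl in place, whereas here the isopropylsulfonyl leaves and a (piperidin-1-yl)carbonyl enters. Among the measured compounds shown here, with that step as the sole guide, the expectation for compound 3 is a step of a 2.0-fold higher number from compound 1 to compound 3 (0.30 log units; within the scatter) that stays within the scatter in this assay, with no clear direction. The estimate for compound 3 is therefore 0.2 10^-6 cm/s, with a range from 0.05 10^-6 cm/s to 0.8 10^-6 cm/s.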

Compound 3, apparent permeability: 0.6 10^-6 cm/s
Estimate against measurement, compound 3: 3.0-fold (0.48 log units) below; the measured number falls inside the stated range.
By their numbers in this assay, from the lowest: compounds 1 and 2 (each within the scatter of the next); then compound 3.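

Taking the sulfonyl off this amine nitrogen in a ring and putting (piperidin-1-yl)carbonyl there moves the read-out in this assay beyond the scatter: there is a 6.0-fold higher number from compound 1 to compound 3 (0.78 log units; beyond the scatter) and likewise a 6.0-fold higher number from compound 2 to compound 3 (0.78 log units; beyond the scatter) in a modest step from each of two different sulfonyl groups. An exchange of one sulfonyl group for another gave only no change at the digits printed from compound 1 to compound 2 (within the scatter) so among these three compounds the higher number goes with the (piperidin-1-yl)carbonyl of compound 3 and with neither sulfonyl group. Nothing measured here accounts for this step.

The compounds shown leave open whether the higher number follows the carbonyl link or the piperidine ring. An acetyl group, with the carbonyl but no ring, and a piperidin-1-ylsulfonyl group, with the ring on a sulfonyl, would separate the two.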